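Fluoro for methoxy on the aryl ring: compound 4

The source may hold more compounds than are shown below. What is called first, only, known or untested is meant among the compounds shown, and "the series" means these compounds.

The series shares one core and varies the aryl ring carrying the acid chain. Compound 1 `Cc1nn(-c2ccccn2)c2cc(-c3ccc(CCC(=O)O)cc3)ccc12` gives 1400 nM in a functional assay on cells for agonist activity at Free fatty acid receptor 1 (Mus musculus), read by FLIPR and calcium flux, with a stated time of 5 min; on this read-out higher numbers stand for an effect only at larger amounts of compound and lower numbers for an effect already at smaller amounts. Compound 2 `Cc1nn(-c2ccccn2)c2cc(-c3ccc(CCCC(=O)O)cc3)ccc12`, which lengthens the chain, gives 2100 nM; the step of a 1.5-fold higher number from compound 1 to compound 2 (0.18 log units; within the scatter) is within the scatter. Compound 3 `COc1cc(CCC(=O)O)ccc1-c1ccc2c(C)nn(-c3ccccn3)c2c1` gives 8200 nM, the highest of the three numbers, beyond the scatter from both others, so it is the least active of the measured set. The step of a 5.9-fold higher number from compound 1 to compound 3 (0.77 log units; beyond the scatter) shows that adding methoxy at this position costs a modest amount.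

Compound 4 `Cc1nn(-c2ccccn2)c2cc(-c3ccc(CCC(=O)O)cc3F)ccc12` is the next step: fluoro in place of methoxy on an aromatic carbon. Among the measured compounds shown here, the only measured step that bears on this position is a 5.9-fold higher number from compound 1 to compound 3 (0.77 log units; beyond the scatter), where the group entered; no measured pair shows fluoro at this place. Since methoxy set compound 3 apart from compound 1 by a 5.9-fold higher number from compound 1 to compound 3 (0.77 log units; beyond the scatter), and fluoro carries fewer heavy atoms and no acceptor, part of that loss is expected to be recovered, while a return all the way to compound 1 is not assumed. The expected step is a 3.3-fold lower number from compound 3 to compound 4 (0.52 log units; beyond the scatter), toward lower numbers. Compound 4 is therefore estimated at 2500 nM in this assay, with a range from 1000 nM to 7000 nM.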

Compound 4, half-maximal effective concentration: 1500 nM
Compound 4: the middle estimate sits 1.7-fold (0.22 log units) above what was measured, within the range that was stated.
By their numbers in this assay, from the lowest: compounds 1, 4 and 2 (each within the scatter of the next); then compound 3.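

Replacing methoxy with fluoro in this assay produces a clear change (a 5.5-fold lower number from compound 3 to compound 4 (0.74 log units; beyond the scatter)), which shows that the cost seen for compound 3 does not extend to every replacement of hydrogen on this aromatic carbon. Against the hydrogen of compound 1, fluoro leaves the read-out unchanged within the scatter (a 1.1-fold higher number from compound 1 to compound 4 (0.03 log units; within the scatter)), so this carbon, ortho to a large group and meta to the 2-carboxyethyl group, tolerates at least one substituent, and the penalty so far belongs to methoxy alone among the groups shown. Nothing measured here explains why methoxy and fluoro part ways at this carbon.

The compounds shown leave open which part of methoxy carries the cost, a question that hydroxy, methyl or ethoxy at this carbon would help to settle, and whether chloro or trifluoromethyl behaves like fluoro. They also leave open whether fluoro stays neutral when combined with the longer acid chain of compound 2, and whether any group on this carbon can bring the numbers below those of compound 1 and compound 4.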